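Notes on a 4-bromophenyl replacement in the sulfone series

This account rests on a few compounds, and the source may have more. Where it says the series, first, only, none or still open, it means among the compounds named here.

For the measured compounds named here, the three measured members share one core. Compound 1 `Cc1ccc(-c2c(S(=O)(=O)c3ccccc3)cnc3cc(C)nn23)cc1` carries a methyl on the five-membered ring; in a functional assay on the whole organism for inhibition, with Mus musculus as the target, with a stated time of 5 h, at a dose of 50 mg/kg by the oral route (a higher number here means more inhibition at the dose given (going by the name of the read-out), a lower number less inhibition), compound 1 gives 8.1%. Compound 2 `O=S(=O)(c1ccccc1)c1cnc2ncnn2c1-c1ccc(Br)cc1` gives 0.8%, and compound 3 `Cc1cc2ncc(S(=O)(=O)c3ccccc3)c(-c3ccc(Br)cc3)n2n1` gives 0%. Compound 1 holds the highest of the three numbers, yet its distance to compound 2 and to compound 3 lies within the scatter, so no order among them can be read.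

Compound 4 `Cc1ccc(-c2c(S(=O)(=O)c3ccccc3)cnc3cc(-c4ccc(Br)cc4)nn23)cc1` differs from compound 1 in one place: 4-bromophenyl in place of methyl on an aromatic carbon. Going by the values given here, the only measured step with a single change is a number 8.1 percentage points lower from compound 1 to compound 3 (within the scatter), which concerns the phenyl ring, not the five-membered ring, and stays within the scatter. Compound 2 and compound 3 also sit close to each other. Among the compounds with values here, no measured pair shows an aryl group entering at the place changed in compound 4, so nothing in the data points to a step beyond the scatter in either direction.

Compound 4 is therefore expected to give about 7%, within 0% to 22%. The expected step is a number 1.1 percentage points lower from compound 1 to compound 4 (within the scatter), a change not beyond the scatter.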

Compound 4, a percentage reported as inhibition, in the whole organism at one dose (the size of the read-out at that dose, not a potency): 31.7%
Beside the measured number, compound 4's estimate is 24.7 percentage points below it; measured number above the stated range.
By their numbers in this assay, from the lowest: compounds 3, 2 and 1 (each within the scatter of the next); then compound 4.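

For the compounds shown here, this position is the first place where a single change moves the read-out beyond the scatter: in this assay, 4-bromophenyl in place of methyl on the aromatic carbon of the five-membered ring gives a number 23.6 percentage points higher from compound 1 to compound 4 (beyond the scatter). Going by these compounds alone, the only earlier single change, bromo in place of methyl on the phenyl ring, gave a number 8.1 percentage points lower from compound 1 to compound 3 (within the scatter), so it did not show that any position responds to substitution. The new step shows that this carbon accepts an added aromatic ring with a gain in inhibition at the one dose given, though that says nothing about potency, and nothing available bears on the reason for the gain.

Going by these compounds, it remains open whether the gain needs the aromatic ring itself or the bromine on it, a question that an unsubstituted phenyl at this carbon, or a 4-chlorophenyl, would address. A saturated group such as cyclohexyl, a longer alkyl chain or an amine at the same place would show whether an aromatic ring is required at all.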